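This account rests on a few compounds, and the source may have more. Where it says the series, first, only, none or still open, it means among the compounds named here.

In an assay on isolated protein for inhibition of aldehyde dehydrogenase 1A1 (Homo sapiens), read by spectrophotometry, tested at 10 uM (a lower number here means less inhibition, a higher number more inhibition at the concentration tested (going by the name of the read-out)), compound 1 `O=C(C1CC1)N1CCN(Cc2nc3ccccc3n2Cc2ccc(Cl)cc2)CC1` gives 56.6%, the higher of the two numbers recorded so far. Compound 2 `Cc1cccc(Cn2c(CN3CCN(C(=O)C4CCCCC4)CC3)nc3ccccc32)c1` gives 31.9% in this assay, a gap that lies beyond the usual scatter, though compound 2 differs from compound 1 in more than one place. Compound 3 `Cc1ccccc1Cn1c(CN2CCN(C(=O)C3CC3)CC2)nc2ccccc21` has not yet been measured. It differs from compound 1 in a single place: 2-methylphenyl in place of 4-chlorophenyl on a saturated chain carbon bound to an aromatic nitrogen. Within the data shown here, no pair of measured compounds isolates this change, so its size is uncertain; a moderate fall in inhibition is expected rather than none. Compound 3 is therefore estimated to give 42% in this assay, between 22% and 60%. The expected step is a number 14.6 percentage points lower from compound 1 to compound 3 (beyond the scatter).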

Compound 3, a percentage reported as inhibition, at one concentration (the size of the read-out at that concentration, not a potency): 29.1%
The estimate for compound 3 lay 12.9 percentage points above the measured number; the range from low to high includes it.
By their numbers in this assay, from the lowest: compounds 3 and 2 (each within the scatter of the next); then compound 1.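

Replacing 4-chlorophenyl with 2-methylphenyl on a saturated chain carbon bound to an aromatic nitrogen gives, in this assay, a number 27.5 percentage points lower from compound 1 to compound 3 (beyond the scatter) with nothing else altered. This shows that inhibition depends on the group at this place, which the earlier pair, differing in more than one place, could not show. No measurement shown explains the fall. The change replaces both the chlorine and the methyl's place on the ring, and the compounds shown leave open which of these matters. They also leave open how an unsubstituted phenyl or a 4-methylphenyl would behave here.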